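Taking one methyl off the acid chain

A few compounds are considered here, and "the series" means these few. Any claim that something is new, unique, unknown or untested is made for them only; others in the source may bear on it.

In a functional assay on the whole organism with Mus musculus as the target (on this read-out lower numbers stand for an effect already at smaller amounts and higher numbers for an effect only at larger amounts of compound), compound 2 (`Cc1cc(C(C)CC(=O)O)ccc1-c1noc(-c2ccc(OC(C)C)c(C(F)(F)F)c2)n1`) gives 0.1 mg/kg. Compound 1 (`Cc1cc([C@@H]2C[C@H]2C(=O)O)ccc1-c1noc(-c2ccc(OC(C)C)c(C(F)(F)F)c2)n1`) gives 0.2 mg/kg, which lies within the scatter of compound 2, so neither can be ranked ahead. Compound 3 (`Cc1cc([C@H]2C[C@H]2C(=O)O)ccc1-c1noc(-c2ccc(OC(C)C)c(C#N)c2)n1`) gives 0.7 mg/kg, a higher number than compound 2 shows, and this gap lies beyond the scatter.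

Compound 4 (`Cc1cc(CCC(=O)O)ccc1-c1noc(-c2ccc(OC(C)C)c(C(F)(F)F)c2)n1`) has not yet been measured. Its structure differs from that of compound 2 in one small way: hydrogen in place of methyl on a saturated chain carbon bound to an aromatic carbon and a saturated chain carbon. In words, this is hydrogen in place of methyl on a saturated chain carbon bound to an aromatic carbon and a saturated chain carbon.

One measured step changes this same acid-bearing group: a 2.0-fold lower number from compound 1 to compound 2 (0.30 log units; within the scatter). Replacing 2-carboxycyclopropyl with 1-(carboxymethyl)ethyl stayed within the scatter, so a step beyond the scatter is not expected here, and no direction can be predicted with confidence. The expected step is a 1.5-fold higher number from compound 2 to compound 4 (0.18 log units; within the scatter). For compound 4, the estimated value is 0.15 mg/kg, with an expected range from 0.05 mg/kg to 0.45 mg/kg.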

Compound 4, dose for half-maximal effect: 0.3 mg/kg
Estimate against measurement, compound 4: 2.0-fold (0.30 log units) below, and the stated range covers the measured number.
By their numbers in this assay, from the lowest: compounds 2, 1 and 4 (each within the scatter of the next, the first and the last beyond it); then compound 3.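

In this assay, the methyl on the saturated chain carbon bound to an aromatic carbon and a saturated chain carbon has a measurable effect: replacing it with hydrogen gives a 3.0-fold higher number from compound 2 to compound 4 (0.48 log units; beyond the scatter) and is a modest change that clears the usual scatter. The unbranched 2-carboxyethyl group still holds up against the ring-containing 2-carboxycyclopropyl group, with a 1.5-fold higher number from compound 1 to compound 4 (0.18 log units; within the scatter) showing that these two cannot be ranked. Nothing available explains the effect of the methyl on this whole-animal read-out.

As far as these compounds go, whether an ethyl or a hydroxyl group on that same carbon would give a lower or a higher number than the methyl remains open. So does the effect of a longer chain between the aromatic carbon and the carboxylic acid.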